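Bromo Substitution on a Shared Core: One Measured Step

This account rests on a few compounds, and the source may have more. Where it says the series, first, only, none or still open, it means among the compounds named here.

Measured compounds:
compound 1, `COc1ccc(C2CC(c3ccc4ccccc4c3)=NN2C2=NC(=O)/C(=C3\C(=O)Nc4ccccc43)S2)cc1`, 17500 nM
compound 2, `COc1ccc(C2CC(c3ccc4ccccc4c3)=NN2C2=NC(=O)/C(=C3\C(=O)Nc4ccc(Br)cc43)S2)cc1`, 130 nM
compound 3, `CN(C)c1ccc(C2CC(c3ccccc3)=NN2C2=NC(=O)/C(=C3\C(=O)Nc4ccccc43)S2)cc1`, 33900 nM

Compounds 1, 2 and 3 were tested in a functional assay on cells (Leukemia cell, Homo sapiens) for cytotoxicity, read by sulforhodamine B assay, with a stated time of 48 h; a higher number here means a weaker inhibitor of growth, a lower number a stronger inhibitor of growth. Compound 2 differs from compound 1 by bromo in place of hydrogen on an aromatic carbon, and this change gave a 130-fold lower number from compound 1 to compound 2 (2.13 log units; beyond the scatter). Compound 3 has a different core from compound 1; the difference between the two cores is not broken down here. In this assay compound 3 gives 33900 nM, which lies within the scatter of compound 1.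

Compound 4, `CN(C)c1ccc(C2CC(c3ccccc3)=NN2C2=NC(=O)/C(=C3\C(=O)Nc4ccc(Br)cc43)S2)cc1`, has not yet been measured. Within the data shown here, it differs from compound 3 by bromo in place of hydrogen on an aromatic carbon, the same change as the one from compound 1 to compound 2, at the same place. Because the step of a 130-fold lower number from compound 1 to compound 2 (2.13 log units; beyond the scatter) was large and compound 3 stands close to compound 1, a step of similar direction is expected for compound 4, estimated as an 85-fold lower number from compound 3 to compound 4 (1.93 log units; beyond the scatter). Compound 4 is therefore expected to give about 400 nM in this assay, with a likely range from 100 nM to 3000 nM.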

Compound 4, concentration for 50% growth inhibition: 310 nM
For compound 4 the middle estimate is 1.3-fold (0.11 log units) above the measured one; the measured number falls inside the stated range.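

In this assay, bromo in place of hydrogen on an aromatic carbon gave a 110-fold lower number from compound 3 to compound 4 (2.04 log units; beyond the scatter). Set beside the earlier step, the change carried over from one core to the other with no difference in size beyond the scatter: the same change on two cores in this assay, a 130-fold lower number (2.13 log units; beyond the scatter) from compound 1 to compound 2 and a 110-fold lower number (2.04 log units; beyond the scatter) from compound 3 to compound 4, 1.2-fold (0.09 log units) apart, within the scatter of two such steps. This shows that the step held on these two cores, but it does not show that it would hold on any other core, and it gives no reason why the change acts as it does.

The compounds shown leave open whether chloro, fluoro or methyl at the same place would give a step of similar size. They also leave open what an amine or a carboxylic acid there would do.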